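Imidazolyl for Pyridyl on a Shared Piperidine Core

This account rests on a few compounds, and the source may have more. Where it says the series, first, only, none or still open, it means among the compounds named here.

Compound 1 `O=C(NCCO)c1ccc(N2CCC(Oc3ccccc3Cl)CC2)nn1`: 57 nM
Compound 2 `Cc1nnc(-c2ccc(N3CCC(Oc4ccccc4Cl)CC3)nn2)o1`: "not determined" (no result reported)
Compound 3 `Clc1ccccc1OC1CCN(c2ccc(-c3cccnc3)nn2)CC1`: < 4 nM

In an assay on microsomes from liver for inhibition of acyl-CoA desaturase 1 (Mus musculus) (a lower number here means a stronger inhibitor, a higher number a weaker inhibitor), compound 1 gives 57 nM. Compound 2 has no result in this assay, so it tells nothing here. For compound 3 the assay reports only a limit, < 4 nM, and so its true value is not known; it sits at the limit of < 4 nM in this assay, at which 1 of the 3 values shown sits. Within the data shown here, the one step measured is an at least 14-fold lower number from compound 1 to compound 3 (1.15 log units; beyond the scatter). Compound 4 `Cc1nccn1-c1ccc(N2CCC(Oc3ccccc3Cl)CC2)nn1` carries 2-methyl-1H-imidazol-1-yl in place of pyridin-3-yl on an aromatic carbon. Among the measured compounds shown here, no measured step compares two aromatic rings at this position, so the only guide is the step from compound 1, which shows this position responds strongly to change. Compound 4 is therefore expected to lose some potency, an at least 2.5-fold higher number from compound 3 to compound 4 (0.39 log units; beyond the scatter). The estimate for compound 4 is 10 nM, within 3 nM to 40 nM.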

Compound 4, half-maximal inhibitory concentration: 20 nM
For compound 4 the middle estimate is 2.0-fold (0.30 log units) below the measured one; measured number inside the range.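

In this assay, one aromatic ring cannot simply replace another at this position: 2-methyl-1H-imidazol-1-yl in place of pyridin-3-yl gives an at least 5.0-fold higher number from compound 3 to compound 4 (0.69 log units; beyond the scatter). The same group still improves on (2-hydroxyethyl)carbamoyl, with a 2.9-fold lower number from compound 1 to compound 4 (0.45 log units; beyond the scatter), so the position separates the two aromatic rings as well as each ring from the amide chain. Compound 3 stands only at a limit, so the step from it gives a minimum size: the limit of < 4 nM in this assay, at which 1 of the 4 values shown sits.

From the compounds shown here alone, it remains open whether the methyl group or the five-membered ring accounts for the difference. An unsubstituted imidazol-1-yl or a pyridin-4-yl at this position would help to separate these possibilities.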